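The source may report more compounds than this note shows. Statements on the series, on what has been measured and on what is new or still open speak of the compounds shown alone.

Series notes. Within the data shown here, the shared core is that of compound 1 `CCCNc1nc(-c2ccccc2)nc2c1nnn2Cc1ccccc1`, which in an assay on isolated protein for binding affinity to adenosine receptor A1 (Bos taurus) (on this read-out lower numbers stand for stronger inhibition and higher numbers for weaker inhibition), gives 37000000 nM, the highest of the three numbers so far. Compound 2 `Clc1ccccc1Cn1nnc2c(NC3CCCC3)nc(-c3ccccc3)nc21` carries a ring on the amine nitrogen and a chloro on the benzyl ring and gives 9000000 nM in this assay. Compound 3 `CCCNc1nc(-c2ccccc2)nc2c1nnn2Cc1ccccc1F` differs from compound 1 only at the benzyl ring; compound 3 gives 3200000 nM, and the single-point change is a 12-fold lower number from compound 1 to compound 3 (1.06 log units; beyond the scatter).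

The step to compound 4 `O[C@H]1CCCC[C@@H]1Nc1nc(-c2ccccc2)nc2c1nnn2Cc1ccccc1` replaces the propyl on the amine nitrogen: 2-hydroxycyclohexyl in place of propyl on a nitrogen on an aromatic ring. Among the measured compounds shown here, no measured step isolates a change at this nitrogen. For the measured compounds named here, the only measured step, the fluoro change from compound 1 to compound 3, sits elsewhere on the molecule and gives no guide here. Compound 2 does carry a ring in place of the propyl and shows a lower number than compound 1, but its chloro substituent is changed at the same time, so the two values cannot be split into parts.

With nothing directly bearing on the change, a modest lowering is expected, as a 3.7-fold lower number from compound 1 to compound 4 (0.57 log units; beyond the scatter). Compound 4 is estimated at 10000000 nM, within 2000000 nM to 40000000 nM.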

Compound 4, inhibition constant: 10300000 nM
The estimate for compound 4 lay 1.0-fold (0.01 log units) below the measured number; the measured number falls inside the stated range.
By their numbers in this assay, from the lowest: compound 3; then compounds 2 and 4 (each within the scatter of the next); then compound 1.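

Among these compounds, the first measured step at this nitrogen on an aromatic ring is the exchange of propyl for 2-hydroxycyclohexyl, which in this assay gives a 3.6-fold lower number from compound 1 to compound 4 (0.56 log units; beyond the scatter) and is read as a modest change beyond the scatter. The position therefore accepts a group with more heavy atoms, one six-membered non-aromatic ring of carbon only and a hydrogen-bond donor without the number rising, which compound 2 could not show as its chloro changes at the same time. The ring, the hydroxy group and the 2 defined stereocentres enter together in this single step, so its size cannot be divided among them, and no measurement at hand gives a reason for the lower number.

Still open, from the compounds shown here alone, is how much of the step would remain with plain cyclohexyl on the nitrogen, or with the opposite stereoisomer of 2-hydroxycyclohexyl. Also open, going by these compounds, is whether a longer chain or a chain ending in a carboxylic acid would move the number in the same direction, and whether 2-hydroxycyclohexyl and a fluoro on the benzyl ring would combine.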